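The source may report more compounds than this note shows. Statements on the series, on what has been measured and on what is new or still open speak of the compounds shown alone.

In a functional assay on the whole organism for inhibition, with Cavia porcellus as the target (on this read-out lower numbers stand for an effect already at smaller amounts and higher numbers for an effect only at larger amounts of compound), compound 1 (`COc1ccccc1OCC1SCCN1C(=O)Cn1ccnc1`) gives 50 mg/kg and compound 2 (`COc1ccc(OCC2SCCN2C(=O)Cn2ccnc2)cc1`) gives 48 mg/kg (the two values lie within the scatter of each other). Compound 3 (`COc1ccccc1OCC1N(C(=O)CC(=O)O)CC[S+]1[O-]`) gives 20 mg/kg and so stands beyond the scatter on the lower side of compound 1. Compound 1 therefore sits level with one neighbour and clearly apart from the other.

Compound 4 (`COc1ccccc1OCC1SCCN1C(=O)C(C)(C)C(=O)O`) has not yet been measured. It departs from compound 1 by a single change on a carbonyl carbon, with 1-carboxy-1-methylethyl in place of (1H-imidazol-1-yl)methyl (1-carboxy-1-methylethyl in place of (1H-imidazol-1-yl)methyl on a carbonyl carbon). Within the data shown here, no step between measured compounds isolates this change, so the evidence is indirect. The expectation leans on compound 3 (20 mg/kg), which also carries a carboxy group but differs from compound 1 in more than one place. That comparison supports only a cautious reading, and three compounds establish no trend. An estimated 1.7-fold lower number from compound 1 to compound 4 (0.22 log units; within the scatter) in this assay would be a modest move to a lower number, which may well stay within the scatter. For compound 4 the estimated value is 30 mg/kg with an expected range from 12 mg/kg to 70 mg/kg.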

Compound 4, dose for half-maximal effect: 34 mg/kg
The estimate for compound 4 lay 1.1-fold (0.05 log units) below the measured number, and the stated range covers the measured number.
By their numbers in this assay, from the lowest: compounds 3, 4, 2 and 1 (each within the scatter of the next, the first and the last beyond it).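

In this assay, among these compounds, the change on a carbonyl carbon whose other neighbours are an amide-type nitrogen in a ring gives the series its only single-place comparison (a 1.5-fold lower number from compound 1 to compound 4 (0.17 log units; within the scatter)), and that step lies within the scatter. At this place, therefore, 1-carboxy-1-methylethyl and (1H-imidazol-1-yl)methyl cannot be told apart on this read-out, even though the entering group has no ring and brings a hydrogen-bond donor, whereas the leaving group has a five-membered aromatic ring and no such donor. Nothing available explains this outcome, so the result stands as an observation only.

Among the compounds shown here, the single step does not show whether the carboxy group or the methyl groups of 1-carboxy-1-methylethyl contribute anything on their own, and a carboxymethyl group or a dimethylaminomethyl group at the same place would help to separate those parts. From the compounds shown here alone, it also remains open whether the same exchange gives a comparable result on the core of compound 2, where the same imidazolylmethyl group is present.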